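Cytotoxicity in the series: a step to methoxy

The source may report more compounds than this note shows. Statements on the series, on what has been measured and on what is new or still open speak of the compounds shown alone.

Of the compounds shown here, two have been read in a toxicity assay on NIH3T3 cells (Mus musculus) for cytotoxicity, read by resazurin assay; a lower number here means that less compound is needed, a higher number that more compound is needed for the effect. Compound 1 `CC(=O)c1ccc(NCc2cncn2Cc2ccc(-c3ccccc3)cc2)cc1-c1ccccc1` sits at the limit of the assay, with compound 1 giving > 10000 nM, a limit and not a number. Compound 2 `CC(C)OC(=O)c1ccc(NCc2cncn2Cc2ccc(-c3ccccc3)cc2)cc1-c1ccccc1` likewise sits at the limit, with compound 2 giving > 10000 nM. Among the measured compounds shown here, the one step between measured compounds, a step that the two limits leave unreadable from compound 1 to compound 2, is therefore of unknown size, as both of its values are limits; this is summed up by the limit of > 10000 nM in this assay, at which 2 of the 2 values shown sit.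

Compound 3 `COc1ccc(NCc2cncn2Cc2ccc(-c3ccccc3)cc2)cc1-c1ccccc1` is not yet measured. It differs from compound 2 by methoxy in place of isopropoxycarbonyl on an aromatic carbon. For the measured compounds named here, no measured step bears directly on this change: the only step available, from a methyl to an isopropoxy group on the carbonyl carbon, is unreadable, and both compounds that share the core stand at the limit. On that basis no step beyond the scatter is expected in this assay for compound 3, and the most likely outcome is again a limit. The expected step that the limit leaves unreadable from compound 2 to compound 3 is no more than the scatter. Compound 3 is estimated at 20000 nM, with a range from 10000 nM to 60000 nM.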

Compound 3, half-maximal effective concentration: > 1000 nM
Compound 3 gave a limit, no number (the forecaster's own chance of this, stated with the estimate: 85%); the middle value lies beyond the limit too.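

In this assay compound 3 gives > 1000 nM, a limit and not a number. Among the compounds shown here, the values of compound 1, compound 2 and compound 3 are all limits, and no step among them can be read. The compounds shown leave open how these three compare in this assay, and at what concentration any of them reaches the half-maximal effect.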